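The source may report more compounds than this note shows. Statements on the series, on what has been measured and on what is new or still open speak of the compounds shown alone.

Compound 1 `Cc1cc(C)c2cccc(OCc3c(Cl)ccc(S(=O)(=O)NC4(C(=O)N5CCN(C(=O)CCCCC[N+](C)(C)C)CC5)CCCC4)c3Cl)c2n1`, compound 2 `Cc1cc(C)c2cccc(OCc3c(Cl)ccc(S(=O)(=O)NC4(C(=O)N5CCN(C(=O)[C@H](CCCC[N+](C)(C)C)[N+](C)(C)C)CC5)CCCC4)c3Cl)c2n1` and compound 3 `Cc1cc(C)c2cccc(OCc3c(Cl)ccc(S(=O)(=O)NC4(C(=O)N5CCN(C(=O)[C@@H](N)CCC[N+](C)(C)C)CC5)CCCC4)c3Cl)c2n1` share one core and differ only in the tail that hangs from the carbonyl of the piperazine amide. In an assay on isolated protein for binding affinity to B1 bradykinin receptor (Homo sapiens) (a lower number here means a stronger inhibitor, a higher number a weaker inhibitor), compound 1 gives a limit of < 10000 nM, not a number. In this assay compound 2 likewise gives only a limit of < 10000 nM. In this assay compound 3 also stands at a limit of < 10000 nM, so its place among the three is not fixed by a number. The step that the two limits leave unreadable from compound 1 to compound 2 and the step that the two limits leave unreadable from compound 1 to compound 3 therefore cannot be read, since (the limit of < 10000 nM in this assay, at which 3 of the 3 values shown sit).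

Compound 4 `Cc1cc(C)c2cccc(OCc3c(Cl)ccc(S(=O)(=O)NC4(C(=O)N5CCN(C(=O)[C@H](CCC[N+](C)(C)C)[N+](C)(C)C)CC5)CCCC4)c3Cl)c2n1` comes from compound 3 by the change (a group of 4 heavy atoms (3 carbon, 1 nitrogen; no ring) in place of one nitrogen atom, on a saturated chain carbon bound to a carbonyl carbon and a saturated chain carbon). The closest measured step, from compound 1 to compound 2, adds the same kind of group at the same kind of place, but its size is hidden by the limits. With nothing readable to lean on, the step that the limit leaves unreadable from compound 3 to compound 4 is expected to stay within the scatter, and compound 4 is estimated at 3000 nM in this assay, with a likely range from 300 nM to 10000 nM.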

Compound 4, inhibition constant: < 10000 nM
Compound 4: no number, only a limit; the forecaster's own chance of this, stated with the estimate: 60%; the middle value is on the limit's open side.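

Among these compounds, compound 4 also gives only a limit in this assay, not a number, so no step linking it to compound 1, compound 2 or compound 3 can be read: the limit of < 10000 nM in this assay, at which 4 of the 4 values shown sit. The compounds shown leave open how these four tails rank against one another in this assay.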